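Swapping a Methoxyphenyl for a Chlorophenyl on the Core

The compounds below may be only part of what the source reports. "The series", "measured", "known", "first", "only" and "open" are said of these compounds alone.

Two measured compounds frame this step. Compound 1 `CC[C@@H](Nc1c(C#N)c(-c2ccc(-c3ccc(OC)cc3)cc2)nc2cnccc12)C(N)=O` stands at the lower end of the two numbers available in a physicochemical assay for lipophilicity, read by HPLC, at pH 7.5; on this read-out higher numbers stand for higher lipophilicity and lower numbers for lower lipophilicity: in this assay compound 1 gives 2.7. Among the compounds with values here, compound 2 `CCCCC(Nc1c(C#N)c(-c2ccc(-c3ccccc3OCC)cc2)nc2cnccc12)C(N)=O` differs from compound 1 in several places at once, so no single step can be drawn between them; in this assay compound 2 gives 3.6, a number higher than that of compound 1 by more than the usual scatter of repeated measurements.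

Within the data shown here, the new compound 3 `CC[C@@H](Nc1c(C#N)c(-c2ccc(-c3ccccc3Cl)cc2)nc2cnccc12)C(N)=O` changes compound 1 in one place: 2-chlorophenyl in place of 4-methoxyphenyl on an aromatic carbon No step between measured compounds that differ in one place is available, so the size of this change is not anchored by a measured example. The step from compound 1 to compound 3 is expected to be a number 0.60 log units higher from compound 1 to compound 3 (beyond the scatter), an increase that would go beyond the scatter. In this assay compound 3 is expected to come out near 3.3, with a likely range from 2.9 to 3.7.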

Compound 3, distribution coefficient: 2.9
For compound 3 the middle estimate is 0.40 log units above the measured one; the measured number falls inside the stated range.
By their numbers in this assay, from the lowest: compounds 1 and 3 (each within the scatter of the next); then compound 2.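

In this assay, 2-chlorophenyl in place of 4-methoxyphenyl, on an aromatic carbon para to a large group, gives a number 0.20 log units higher from compound 1 to compound 3 (within the scatter). Within the data shown here, this is the first step at this position that changes one place only, and it shows that this read-out does not separate the two groups, although 4-methoxyphenyl has 8 heavy atoms and 1 hydrogen-bond acceptor while 2-chlorophenyl has 7 heavy atoms and 0 hydrogen-bond acceptors. The step alters the group and its point of attachment on the ring together, so it cannot assign any share of the outcome to either one, and no measurement at hand offers an explanation for it.

The compounds shown leave open how 4-chlorophenyl or 2-methoxyphenyl would read at this place, which would pull apart the choice of group from its place on the ring. Also open, going by these compounds, are how a phenyl ring carrying an amine or a carboxylic acid would read here, and whether the same exchange would give a similar step on a compound with the longer chain of compound 2.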